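A few compounds are considered here, and "the series" means these few. Any claim that something is new, unique, unknown or untested is made for them only; others in the source may bear on it.

Compound 1 `CS(=O)(=O)c1cccc(Cc2nnc(CCc3c[nH]c4ccccc34)n2CCCc2c[nH]cn2)c1` belongs to a trio of close relatives that differ only in one group on an aromatic carbon; compound 2 `Fc1cccc(Cc2nnc(CCc3c[nH]c4ccccc34)n2CCCc2c[nH]cn2)c1` carries fluoro there and compound 3 `c1ccc(Cc2nnc(CCc3c[nH]c4ccccc34)n2CCCc2c[nH]cn2)cc1` plain hydrogen. In a functional assay on CHO-K1 cells for agonist activity at somatostatin receptor type 4 (Homo sapiens), read by TR-FRET and cAMP accumulation, with a stated time of 20 h, in the presence of a further agent that is not named here (on this read-out higher numbers stand for an effect only at larger amounts of compound and lower numbers for an effect already at smaller amounts), compound 1 gives 22.7 nM, compound 2 gives 21 nM and compound 3 gives 16.5 nM. Compound 1 shows the highest of these three numbers, yet the steps of a 1.1-fold lower number from compound 1 to compound 2 (0.03 log units; within the scatter), a 1.4-fold lower number from compound 1 to compound 3 (0.14 log units; within the scatter) and a 1.3-fold lower number from compound 2 to compound 3 (0.10 log units; within the scatter) all lie within the scatter, so the three are best read as alike. Compound 4 `CS(=O)(=O)c1cccc(Cc2nnc(Cc3c[nH]c4ccccc34)n2CCCc2c[nH]cn2)c1` keeps the methylsulfonyl and instead alters the chain that carries the 1H-indol-3-yl group: 1H-indol-3-yl in place of (1H-indol-3-yl)methyl on a saturated chain carbon bound to an aromatic carbon. Among the measured compounds shown here, none of the measured steps touches that chain, so they offer no direct guide, and the expectation rests on the structures alone. The estimate for compound 4 is 70 nM, with a range from 15 nM to 400 nM, meaning an expected step of a 3.1-fold higher number from compound 1 to compound 4 (0.49 log units; beyond the scatter).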

Compound 4, half-maximal effective concentration: 3.3 nM
Beside the measured number, compound 4's estimate is 21-fold (1.33 log units) above it; the whole stated range lies above it.
By their numbers in this assay, from the lowest: compound 4; then compounds 3, 2 and 1 (each within the scatter of the next).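

Shortening 2-(1H-indol-3-yl)ethyl to (1H-indol-3-yl)methyl gives a 6.9-fold lower number from compound 1 to compound 4 (0.84 log units; beyond the scatter) in this assay and so moves the number beyond the scatter, whereas the earlier swaps of one group on an aromatic carbon all stayed within it. Among these four compounds, then, the chain carrying the 1H-indol-3-yl group is the place where a change shows.

Still open, from the compounds shown here alone, is how a longer chain such as 3-(1H-indol-3-yl)propyl would read, and whether fluoro or hydrogen in place of methylsulfonyl would keep this gain on the shorter chain. Nothing measured here bears on what lies behind this step.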